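The source may hold more compounds than are shown below. What is called first, only, known or untested is meant among the compounds shown, and "the series" means these compounds.

Working notes on the benzylpurine pair and its next member.

Of the compounds shown here, two have numbers so far. Compound 1 `ClCc1ccccc1Cn1cnc2c(Cl)nc(Cl)nc21` is the lower of the two in a functional assay on HOP-92 cells (Homo sapiens) for cytotoxicity, read by sulforhodamine B assay, with a stated time of 48 h (on this read-out higher numbers stand for weaker inhibition of growth and lower numbers for stronger inhibition of growth), where compound 1 gives 350 nM. Compound 2 `ClCc1cccc(Cn2cnc3c(Cl)nc(Cl)nc32)c1`, the other measured member, gives 1820 nM in this assay; the gap between the two lies beyond the usual scatter, so compound 1 stands as the lower-reading entry of the two, and nothing more can be said of an order within this small set.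

The step now followed goes from compound 1 to compound 3 `Nc1nc(Cl)c2ncn(Cc3ccccc3CCl)c2n1`. The change is amino in place of chloro on an aromatic carbon, in words: amino in place of chloro on an aromatic carbon. Among the measured compounds shown here, no measured pair shows this exchange, so its size is not known from the data at hand. The expectation for this assay is a modest move toward a higher number, that is, toward weaker inhibition of growth, of a size near the edge of the scatter or somewhat beyond it, rather than a large jump; the expected step from compound 1 to compound 3 is a 2.9-fold higher number from compound 1 to compound 3 (0.46 log units; beyond the scatter). On that basis compound 3 is estimated at 1000 nM in this assay, with a range from 300 nM to 4000 nM.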

Compound 3, concentration for 50% growth inhibition: 6460 nM
Compound 3: the middle estimate sits 6.5-fold (0.81 log units) below what was measured, outside the stated range (above it).
By their numbers in this assay, from the lowest: compound 1; then compound 2; then compound 3.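

In this assay, the exchange of chloro for amino on the aromatic carbon between two ring nitrogen atoms gives a large step, an 18-fold higher number from compound 1 to compound 3 (1.27 log units; beyond the scatter), toward weaker inhibition of growth. Among the compounds shown here, this is the first direct reading at this position, and it shows that, with the rest of compound 1 unchanged, the reading depends strongly on which group sits on this carbon. No measurement at hand accounts for the size of the step, so it stands here as an observation without an assigned reason.

Still open, going by these compounds, is whether this step is specific to amino or would follow any replacement of chloro at this place; a methoxy, methylamino or dimethylamino group on the same carbon would help separate those two readings. Also open is whether the exchange gives a step of similar size when the chloromethyl group sits as it does in compound 2, since the compounds shown offer only the single pair from compound 1 to compound 3.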